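The source may report more compounds than this note shows. Statements on the series, on what has been measured and on what is new or still open speak of the compounds shown alone.

Notes on the series. Compound 3 `Nc1ccc(S(=O)(=O)N2CCN(c3ncc(C(O)(C(F)(F)F)C(F)(F)F)cc3-c3ccccc3O)CC2)cn1` sits alongside compound 1 `CC(C)(O)C#Cc1cc(C(O)(C(F)(F)F)C(F)(F)F)cnc1N1CCN(S(=O)(=O)c2ccc(N)nc2)CC1` and compound 2 `CCn1cc(-c2cc(C(O)(C(F)(F)F)C(F)(F)F)cnc2N2CCN(S(=O)(=O)c3ccc(N)nc3)CC2)cn1`, which share its core. In an ADME assay (liver) for metabolic stability, with Liver microsome (Rattus norvegicus) as the target, using microsomes and NADPH, with a stated time of 30 min, tested at 1 uM (on this read-out higher numbers stand for fast clearance and lower numbers for slow clearance), compound 1 gives 16 mL.min-1.g-1, compound 2 gives 194 mL.min-1.g-1 and compound 3 gives 125 mL.min-1.g-1. Compound 3 thus stands second highest of the three, with a 1.6-fold lower number from compound 2 to compound 3 (0.19 log units; within the scatter) and a 7.8-fold higher number from compound 1 to compound 3 (0.89 log units; beyond the scatter); the remaining step is a 12-fold higher number from compound 1 to compound 2 (1.08 log units; beyond the scatter). Compound 4 `Nc1ccc(S(=O)(=O)N2CCN(c3ncc(C(O)(C(F)(F)F)C(F)(F)F)cc3-c3ccc4ocnc4c3)CC2)cn1` differs from compound 3 by 1,3-benzoxazol-5-yl in place of 2-hydroxyphenyl on an aromatic carbon. The step bearing most directly on this is the exchange of one aromatic substituent for another on the same aromatic carbon, a 1.6-fold lower number from compound 2 to compound 3 (0.19 log units; within the scatter), which stayed within scatter; the two large steps both replaced 3-hydroxy-3-methylbut-1-yn-1-yl and do not apply here. No shift beyond scatter is expected in this assay. Compound 4 is estimated at 130 mL.min-1.g-1, range 60 mL.min-1.g-1 to 280 mL.min-1.g-1. This corresponds to an expected step of a 1.0-fold higher number from compound 3 to compound 4 (0.02 log units; within the scatter).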

Compound 4, intrinsic clearance in microsomes: 120 mL.min-1.g-1
Compound 4: the middle estimate sits 1.1-fold (0.03 log units) above what was measured; low and high end bracket the measured number.
By their numbers in this assay, from the lowest: compound 1; then compounds 4, 3 and 2 (each within the scatter of the next).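

In this assay, 1,3-benzoxazol-5-yl in place of 2-hydroxyphenyl gives a 1.0-fold lower number from compound 3 to compound 4 (0.02 log units; within the scatter), so a second ring and the absence of a hydrogen-bond donor in the entering group leave the number within the scatter. The step of a 1.6-fold lower number from compound 2 to compound 4 (0.21 log units; within the scatter) also stays within the scatter, whereas a 7.5-fold higher number from compound 1 to compound 4 (0.88 log units; beyond the scatter) lies beyond it and leaves compound 1 alone at the low end. No measurement at hand accounts for these steps. Open, going by these compounds, is whether the low number of compound 1 follows the alkyne or its hydroxyl group. An amine or a carboxylic acid on this aromatic carbon would test how far the number can move.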